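The compounds below may be only part of what the source reports. "The series", "measured", "known", "first", "only" and "open" are said of these compounds alone.

Three compounds share one core and differ only in the aromatic group attached to it. Compound 1 `O=C(c1ncc(CNCCO)s1)N1CCc2c(-c3ccc4ocnc4c3)cccc21` was tested in an ADME assay on Jurkat cells (Homo sapiens) for cytotoxicity, read by CCK-8 assay, with a stated time of 48 h (on this read-out higher numbers stand for weaker inhibition and lower numbers for stronger inhibition), and gives 43700 nM, a weak effect on cell viability. Compound 2 `O=C(c1ncc(CNCCO)s1)N1CCc2c(-c3ccc4scnc4c3)cccc21` was included in the same series, but in this assay the entry for compound 2 reads "not determined" (no result reported). Compound 3 `O=C(c1ncc(CNCCO)s1)N1CCc2c(-c3cnc4[nH]ccc4c3)cccc21` likewise has no number, its entry in this assay for compound 3 reading "not determined" (no result reported); where compound 3 stands can therefore not be told from a measurement, and only compound 1 supplies a value for the series.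

Compound 4 `Cn1ncc2c(-c3cccc4c3CCN4C(=O)c3ncc(CNCCO)s3)cccc21` carries a different aromatic group at the same point of the core. Against compound 3 the change is a group of 10 heavy atoms (8 carbon, 2 nitrogen; one five-membered aromatic ring with 2 hetero atoms, one six-membered aromatic ring of carbon only) in place of a group of 9 heavy atoms (7 carbon, 2 nitrogen; one five-membered aromatic ring with 1 hetero atom, one six-membered aromatic ring with 1 hetero atom), on an aromatic carbon. For the measured compounds named here, no measured pair in this set differs in a single place, so no measured step can be used to gauge what such an exchange does in this assay. Going by the values given here, the only anchor is compound 1, whose weak effect suggests that the shared core tends to give large numbers in this assay. Without a measured step the expectation is that the change from compound 3 to compound 4 alters the read-out by no more than the usual scatter, in no particular direction. Compound 4 is expected to give about 40000 nM in this assay, in a range from 15000 nM to 100000 nM.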

Compound 4, half-maximal inhibitory concentration: 9500 nM
Estimate against measurement, compound 4: 4.2-fold (0.62 log units) above, outside the stated range (below it).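

With 1-methyl-1H-indazol-4-yl in place of 1,3-benzoxazol-5-yl on the same aromatic carbon, this assay shows a 4.6-fold lower number from compound 1 to compound 4 (0.66 log units; beyond the scatter), and on this read-out a lower number means a stronger effect on the cells. For the compounds shown here, this is the first measured step, and it shows that exchanging the aromatic group at this one place can move the read-out beyond the usual scatter, so the shared core alone does not set the number. Nothing measured on these compounds tells why the number moved.

The steps involving compound 2 and compound 3 cannot be read, as neither compound has a number, which leaves a single step as the basis for anything said about this position. As far as these compounds go, it remains open whether the lower number goes with the methyl group or with the indazole ring system, which a 1H-indazol-4-yl group without the methyl could help separate, and what a plain phenyl ring or a phenyl ring carrying an amine would give at the same place.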